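The source may hold more compounds than are shown below. What is called first, only, known or untested is meant among the compounds shown, and "the series" means these compounds.

The measured compounds:

Compound 1 `O=c1ccoc2cc(OCc3cn(Cc4ccc([N+](=O)[O-])cc4)nn3)ccc12`: in a functional assay on QGY7701 cells (Homo sapiens) for cytotoxicity, read by MTT assay, with a stated time of 48 h (a lower number here means a stronger inhibitor, a higher number a weaker inhibitor), compound 1 gives only a limit, > 100000 nM.
Compound 2 `N#Cc1ccc(Cn2cc(COc3ccc4c(=O)ccoc4c3)nn2)cc1`: in this assay compound 2 also gives only a limit, > 100000 nM.

Compound 2 therefore stands at the edge of what this assay can report, not at a number; its measurement is a limit, and the other value shown is a limit as well. Within the data shown here, the one measured step, a step that the two limits leave unreadable from compound 1 to compound 2, is unreadable, because of the limit of > 100000 nM in this assay, at which 2 of the 2 values shown sit, so it gives no guidance on how strongly a change on that aromatic carbon can move the read-out.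

The step to compound 3 `COc1ccc(Cn2cc(COc3ccc4c(=O)ccoc4c3)nn2)cc1` is methoxy in place of cyano on an aromatic carbon; seen one bond further out, it reads as 4-cyanobenzyl to 4-methoxybenzyl. Among the measured compounds shown here, no measured step bears on it in a readable way, so the only basis for an expectation is that both compounds sharing the core sit at the limit. Compound 3 is expected to stay in that region, with an estimated step that the limit leaves unreadable from compound 2 to compound 3. For compound 3 the estimated value in this assay is 150000 nM, within a range from 40000 nM to 600000 nM.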

Compound 3, half-maximal inhibitory concentration: 56600 nM
For compound 3 the middle estimate is 2.7-fold (0.42 log units) above the measured one; low and high end bracket the measured number.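

Among these compounds, on this aromatic carbon, para to a large group, methoxy brings the first real number in this assay: compound 3 gives 56600 nM, so a change at this place can bring the read-out into the range where it can be measured. Putting methoxy in place of cyano gives an at least 1.7-fold lower number from compound 2 to compound 3 (0.24 log units; that floor lies within the scatter), and putting it in place of nitro gives an at least 1.7-fold lower number from compound 1 to compound 3 (0.24 log units; that floor lies within the scatter), so neither printed floor alone goes beyond the usual scatter, although the true steps may be larger. Each step is known only as a floor and not as a full size, because one end of each is a limit: the limit of > 100000 nM in this assay, at which 2 of the 3 values shown sit.

On these data alone, how far the number would move with other groups on this carbon, such as an amine, a carboxylic acid or a longer chain ending in an ether oxygen, remains open. With a single readable value, the compounds shown also cannot place cyano and nitro in order or show whether any trend runs across the groups at this place.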